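The compounds below may be only part of what the source reports. "The series", "measured", "known", "first", "only" and "open" are said of these compounds alone.

Measured in an ADME assay on Vero cells (Chlorocebus sabaeus) for cytotoxicity, with a stated time of 5 days; a higher number here means a weaker inhibitor, a lower number a stronger inhibitor:
Compound 1, `C=CCN(C)c1nc(N)nc2c1ncn2[C@H]1C[C@H](N=[N+]=[N-])[C@@H](CO)O1`: 32000 nM
Compound 2, `CNc1nc(Cl)nc2c1ncn2[C@H]1C[C@H](N=[N+]=[N-])[C@@H](CO)O1`: > 100000 nM, which is a limit of the assay rather than a number.
Compound 3, `COc1nc(OC)c2ncn([C@H]3C[C@H](N=[N+]=[N-])[C@@H](CO)O3)c2n1`: > 100000 nM, also a limit of the assay rather than a number.

Among these three, compound 1 stands apart as the only compound with an actual number; the other two sit at the limit of > 100000 nM in this assay, at which 2 of the 3 values shown sit. Within the data shown here, because two of the three results are limits, no step between measured compounds can be worked out, so there is nothing to show how changes on the shared core move cytotoxicity.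

The compound not yet measured is compound 4, `CC(CO)Nc1nc(N)nc2c1ncn2[C@H]1C[C@H](N=[N+]=[N-])[C@@H](CO)O1`. It differs from compound 1 in one place: (1-(hydroxymethyl)ethyl)amino in place of allyl(methyl)amino on an aromatic carbon. Among the measured compounds shown here, with no measured step to lean on, the expectation rests on compound 1 alone. In this assay compound 4 is expected to give 60000 nM, with a range from 20000 nM to 200000 nM. The expected step is a 1.9-fold higher number from compound 1 to compound 4 (0.27 log units; within the scatter), toward weaker inhibition, though it may not clear the usual scatter, and the assay might report only a limit.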

Compound 4, half-maximal inhibitory concentration: > 100000 nM
Compound 4: only a limit was reported; the forecaster's own chance of this, stated with the estimate: 45%; at least 1.6-fold (0.22 log units) between middle value and limit.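

Swapping allyl(methyl)amino for (1-(hydroxymethyl)ethyl)amino gives an at least 3.1-fold higher number from compound 1 to compound 4 (0.49 log units; beyond the scatter) in this assay and is the first readable step in this set, showing that the group on this aromatic carbon can change the result beyond the usual scatter. Compound 4 gives > 100000 nM as a limit of the assay and not a number, so the true size of the step could be larger. Compound 1 remains the only compound here with an actual number, and the ceiling of the assay restricts what can be compared: the limit of > 100000 nM in this assay, at which 3 of the 4 values shown sit.

This single swap does not separate the loss of the allyl group from the gain of the hydroxymethyl group. A plain propylamino group on the same carbon would help tell those two parts apart, and a longer chain ending in a hydroxyl group would show whether chain length also matters.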